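The source may hold more compounds than are shown below. What is called first, only, known or untested is meant among the compounds shown, and "the series" means these compounds.

The three measured compounds in a functional assay on MKN-45 cells (Homo sapiens) for cytotoxicity, read by MTT assay, with a stated time of 72 h; on this read-out lower numbers stand for stronger inhibition and higher numbers for weaker inhibition:

compound 1 `CN(C)CCn1cnnc1-c1cc(Oc2ccc(NC(=O)N/N=C/c3cc(C(C)(C)C)cc(C(C)(C)C)c3O)cc2F)ccn1`, 3300 nM
compound 2 `COc1ccc(/C=N/NC(=O)Nc2ccc(Oc3ccnc(-c4nncn4CCN(C)C)c3)c(F)c2)c(OC)c1OC`, 2020 nM
compound 3 `CN(C)CCn1cnnc1-c1cc(Oc2ccc(NC(=O)N/N=C/c3ccc(F)cc3)cc2F)ccn1`, 1030 nM

Compound 3 gives the lowest of these three numbers. Compound 2 lies within the usual scatter of it, so the two cannot be told apart, whereas compound 1 stands above it by more than the scatter.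

Compound 4 `CN(C)CCn1cnnc1-c1cc(Oc2ccc(NC(=O)N/N=C/c3cc(Br)c(O)c(Br)c3)cc2F)ccn1` has not yet been measured. It differs from compound 3 in one place: 3,5-dibromo-4-hydroxyphenyl in place of 4-fluorophenyl on a carbon with a double bond to nitrogen. For the measured compounds named here, only one measured step concerns an exchange of the aryl group on this carbon, namely a 2.0-fold lower number from compound 2 to compound 3 (0.29 log units; within the scatter), and that step stayed within the scatter. Going by the values given here, compound 1, whose aryl group on the same carbon also carries a hydroxyl, gives 3300 nM, a number beyond the scatter above compound 3, but no single step links those two changes, so it serves only as a loose pointer.

On this basis the exchange is expected to move the number by little, with a modest lean toward a higher value in this assay. The estimate for compound 4 is 1500 nM, with a range from 500 nM to 4500 nM. This corresponds to an expected step of a 1.5-fold higher number from compound 3 to compound 4 (0.16 log units; within the scatter).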

Compound 4, half-maximal inhibitory concentration: 4320 nM
Compound 4: middle estimate off by 2.9-fold (0.46 log units), on the low side; low and high end bracket the measured number.
By their numbers in this assay, from the lowest: compounds 3, 2, 1 and 4 (each within the scatter of the next, the first and the last beyond it).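

In this assay, an exchange of aryl groups on the carbon with a double bond to nitrogen now gives a step beyond the scatter, a 4.2-fold higher number from compound 3 to compound 4 (0.62 log units; beyond the scatter), whereas the earlier exchange at this carbon stayed within it. The new group also stands apart from the 2,3,4-trimethoxyphenyl group, with a 2.1-fold higher number from compound 2 to compound 4 (0.33 log units; beyond the scatter), so the number at this position does depend on which aryl group is attached, and 3,5-dibromo-4-hydroxyphenyl goes with a weaker result than either of the two groups it is compared with here. No measurement is available that explains this change, so only its size can be stated.

From the compounds shown here alone, the exchange brings in the two bromine atoms and the hydroxyl together, so their separate shares remain unknown; a 4-hydroxyphenyl group without bromine and a 3,5-dibromophenyl group without hydroxyl would pull them apart. Going by these compounds, it also remains open whether an amine in place of the hydroxyl, or chlorine in place of the bromine, would keep the number high or bring it back toward that of the 4-fluorophenyl compound.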